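Replacing 3-chlorophenyl on the sulfonamide nitrogen

The source may report more compounds than this note shows. Statements on the series, on what has been measured and on what is new or still open speak of the compounds shown alone.

For the measured compounds named here, in a functional assay on M21 cells (Homo sapiens) for antiproliferative activity, read by sulforhodamine B assay, with a stated time of 48 h (a higher number here means a weaker inhibitor, a lower number a stronger inhibitor), compound 3 `O=C1NCCN1c1ccc(S(=O)(=O)Nc2cccc(Cl)c2)cc1` gives 25 nM, the lowest of the three numbers so far. Compound 1 `O=C1NCCN1c1ccc(S(=O)(=O)Nc2ccc(I)cc2)cc1` gives 260 nM and compound 2 `CCc1ccc(NS(=O)(=O)c2ccc(N3CCNC3=O)cc2)cc1` gives 480 nM. These last two do not separate, with a 1.8-fold higher number from compound 1 to compound 2 (0.27 log units; within the scatter).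

The next structure is compound 4 `Cc1ccc(NS(=O)(=O)c2ccc(N3CCNC3=O)cc2)c(C)c1`, with 2,4-dimethylphenyl in place of 3-chlorophenyl on a sulfonamide nitrogen.

Going by the values given here, two measured steps bear on this change, both large and both beyond the scatter: a 10-fold lower number from compound 1 to compound 3 (1.02 log units; beyond the scatter) and a 19-fold lower number from compound 2 to compound 3 (1.28 log units; beyond the scatter). Each runs from a 4-substituted phenyl to the 3-chlorophenyl of compound 3. The change to compound 4 runs the other way, since its 2,4-dimethylphenyl also carries a group numbered 4. Among these three compounds, no compound goes against the link between a group numbered 4 and the higher number, but three compounds are a thin basis. Among the compounds with values here, no measured compound carries a group numbered 2, so the effect of that methyl is unknown and the range stays wide.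

A step of similar direction and somewhat smaller size is therefore expected: an 8.0-fold higher number from compound 3 to compound 4 (0.90 log units; beyond the scatter), beyond the scatter.

For compound 4 the estimated value in this assay is 200 nM, with an expected range of 50 nM to 800 nM.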

Compound 4, half-maximal inhibitory concentration: 150 nM
For compound 4 the middle estimate is 1.3-fold (0.12 log units) above the measured one; measured number inside the range.
By their numbers in this assay, from the lowest: compound 3; then compounds 4, 1 and 2 (each within the scatter of the next, the first and the last beyond it).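

In this assay, for the compounds shown here, the 2,4-dimethylphenyl on the sulfonamide nitrogen stays clearly short of the 3-chlorophenyl (a 6.0-fold higher number from compound 3 to compound 4 (0.78 log units; beyond the scatter)), so compound 3 now has the lowest number of four, and compounds 1, 2 and 4, which all carry a group numbered 4, stand above it with none going against that link, though compound 3 is the only compound without such a group. The new group also separates from the 4-ethylphenyl (a 3.2-fold lower number from compound 2 to compound 4 (0.51 log units; beyond the scatter)) but not from the 4-iodophenyl (a 1.7-fold lower number from compound 1 to compound 4 (0.24 log units; within the scatter)), so groups that all carry a substituent numbered 4 do not share one level at this position. Nothing given here accounts for these differences.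

A phenyl bearing only one of the two methyl groups would be needed to show how each contributes to the step away from compound 3. Also open, as far as these compounds go, is whether the low number of compound 3 depends on chlorine, and how an aminophenyl or a carboxyphenyl on the same sulfonamide nitrogen would compare with the groups seen so far.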